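A few compounds are considered here, and "the series" means these few. Any claim that something is new, unique, unknown or untested is made for them only; others in the source may bear on it.

Measured so far in a functional assay on T47D cells (Homo sapiens) for inhibition, read by sulforhodamine B assay, with a stated time of 48 h; on this read-out higher numbers stand for weaker inhibition of growth and lower numbers for stronger inhibition of growth:

compound 1 `COc1cc(-c2nn(-c3cccc(NC(=O)c4cccc(C(F)(F)F)c4)c3)cc2-c2ccncc2)ccc1Cl`: 2550 nM
compound 2 `O=C(Nc1cccc(-n2cc(-c3ccncc3)c(-c3ccc(Cl)c(O)c3)n2)c1)Nc1cc(C(F)(F)F)cc(C(F)(F)F)c1`: 1820 nM
compound 3 `O=C(Nc1cccc(-n2cc(-c3ccncc3)c(-c3ccc(Cl)c(O)c3)n2)c1)Nc1ccc(Cl)c(C(F)(F)F)c1`: 1120 nM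

Compound 1 stands highest of the three numbers in this assay; compound 2 lies within the scatter of it, compound 3 beyond it, toward stronger inhibition of growth. Among the compounds with values here, compounds 2 and 3 differ from compound 1 in more than one place, so their numbers give no single step. Compound 4 `COc1cc(-c2nn(-c3cccc(NC(=O)Nc4ccc(Cl)c(Cl)c4)c3)cc2-c2ccncc2)ccc1Cl` remains to be measured. Its change from compound 1 is (3,4-dichlorophenyl)amino in place of 3-(trifluoromethyl)phenyl on a carbonyl carbon. Within the data shown here, no measured pair isolates this change. The expected step of a 1.8-fold lower number from compound 1 to compound 4 (0.26 log units; within the scatter) is a modest move toward stronger inhibition, likely not far beyond the scatter. For compound 4 the estimated value in this assay is 1400 nM, with a range from 500 nM to 4000 nM.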

Compound 4, concentration for 50% growth inhibition: 1420 nM
Compound 4: middle estimate off by 1.0-fold (0.01 log units), on the low side; the measured number falls inside the stated range.
By their numbers in this assay, from the lowest: compounds 3, 4, 2 and 1 (each within the scatter of the next, the first and the last beyond it).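

In this assay, the change from (3-(trifluoromethyl)phenyl)carbonyl to (3,4-dichlorophenyl)carbamoyl gives a 1.8-fold lower number from compound 1 to compound 4 (0.25 log units; within the scatter), so this position takes the carbamoyl form without a step beyond the scatter. The step combines the added amino nitrogen with the change of ring substituents, and neither can be read alone. Nothing at hand bears on the cause of this result. Still open, on these data alone, is the contribution of each chlorine taken singly. Also open, as far as these compounds go, is the effect of a morpholine on the same carbonyl carbon.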